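Metabolic stability in the bicyclic amide series: the benzyl-type substituent

A few compounds are considered here, and "the series" means these few. Any claim that something is new, unique, unknown or untested is made for them only; others in the source may bear on it.

Measured so far:
- compound 1, `CS(=O)(=O)Nc1ccc2c(c1)S(=O)(=O)N=C(C1=C(O)C3CCCC3N(CCC3CC3)C1=O)N2`: 0.417 h
- compound 2, `CS(=O)(=O)Nc1ccc2c(c1)S(=O)(=O)N=C(C1=C(O)C3CCCC3N(Cc3ccc(F)cn3)C1=O)N2`: > 1 h
- compound 3, `CS(=O)(=O)Nc1ccc2c(c1)S(=O)(=O)N=C(C1=C(O)C3CCCCCCC3N(Cc3ccc(F)cc3)C1=O)N2`: > 1 h

Among the measured compounds shown here, compound 1 is the only one with a number in an in vitro ADME assay on microsomes from liver (Homo sapiens) for metabolic stability; on this read-out higher numbers stand for a longer-lived compound and lower numbers for a shorter-lived compound: compound 1 gives 0.417 h. For compound 2 this assay reports only a limit, > 1 h. For compound 3 the read-out is likewise a limit, > 1 h. Compound 2 thus stands at the limit of > 1 h in this assay, at which 2 of the 3 values shown sit, and no number separates it from compound 3.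

For the measured compounds named here, the one measured step at the carbon bound to the ring amide nitrogen is an at least 2.3-fold higher number from compound 1 to compound 2 (0.37 log units; beyond the scatter).

Compound 4, `CS(=O)(=O)Nc1ccc2c(c1)S(=O)(=O)N=C(C1=C(O)C3CCCC3N(Cc3ccc(Cl)cc3)C1=O)N2`, is not yet measured in this assay. It differs from compound 2 by 4-chlorophenyl in place of 5-fluoropyridin-2-yl on a saturated chain carbon bound to an amide-type nitrogen in a ring. Going by the values given here, no measured step covers this exchange; the step from compound 1 to compound 2 only shows that the group on this carbon can shift the result beyond the scatter. Compound 4 is expected to land near the limit, with the step of an at least 1.1-fold lower number from compound 2 to compound 4 (0.04 log units; that floor lies within the scatter) estimated as small. The estimate for compound 4 is 0.9 h, within 0.45 h to 1.8 h.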

Compound 4, half-life: > 1 h
Compound 4 gave a limit, no number (the forecaster's own chance of this, stated with the estimate: 45%); at least 1.1-fold (0.04 log units) between middle value and limit.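

In this assay, 4-chlorophenyl in place of cyclopropylmethyl on the saturated chain carbon bound to the ring amide nitrogen gives an at least 2.3-fold higher number from compound 1 to compound 4 (0.37 log units; beyond the scatter). A second aromatic group at this place, now one of carbon only, therefore also separates from compound 1, so the hetero atom of 5-fluoropyridin-2-yl is not required for this outcome. Most of the read-out for this set now stands at one point: the limit of > 1 h in this assay, at which 3 of the 4 values shown sit.

Going by these compounds, the step between compound 2 and compound 4 cannot be read, as both values are limits, so the order of the two aromatic groups stays unknown. Also open, on these data alone, is whether an aliphatic amine or a carboxylic acid at this place would stay at the limit. The alternative is a result closer to compound 1 at 0.417 h.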